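Replacing amino with methyl in compound 3

This account rests on a few compounds, and the source may have more. Where it says the series, first, only, none or still open, it means among the compounds named here.

Compound 1 `CC(C)(O)c1cn(CC(=O)NCc2ccccc2)nn1`: 1600 uM
Compound 2 `O=C(O)CCCCc1cn(CC(=O)NCc2ccccc2)nn1`: 1080 uM
Compound 3 `Nc1ccc(-c2cn(CC(=O)NCc3ccccc3)nn2)cc1`: 1240 uM

In an ADME assay on cells (spleen, Mus musculus, strain C57BL/6) for inhibition, read by flow cytometry and propidium iodide staining, with a stated time of 24 h, at 37 degrees C (a higher number here means that more compound is needed for the effect, a lower number that less compound is needed), compound 3 gives 1240 uM, and it cannot be separated from the other two compounds: a 1.3-fold lower number from compound 1 to compound 3 (0.11 log units; within the scatter), and a 1.1-fold higher number from compound 2 to compound 3 (0.06 log units; within the scatter). Compound 4 `Cc1ccc(-c2cn(CC(=O)NCc3ccccc3)nn2)cc1` differs from it by one small exchange, (methyl in place of amino on an aromatic carbon), on an aromatic carbon of a six-membered aromatic ring of carbon only, para to a large group.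

Among the measured compounds shown here, no measured step makes this exact exchange. The closest evidence comes from the three steps that replace a whole group on an aromatic carbon, including 4-aminophenyl in place of 4-carboxybutyl. Besides the two steps above, there is a 1.5-fold lower number from compound 1 to compound 2 (0.17 log units; within the scatter). All three stay within the scatter, so no step beyond the scatter is expected in this assay, and no direction can be favoured. The estimated step is a 1.0-fold lower number from compound 3 to compound 4 (0.01 log units; within the scatter). Compound 4 is estimated at 1200 uM, with an expected range from 700 uM to 1900 uM.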

Compound 4, concentration for half-maximal effect: "non-toxic" (no number reported)
For compound 4 the study gives words and no number; no gap can be computed for the estimate.
By their numbers in this assay, from the lowest: compounds 2, 3 and 1 (each within the scatter of the next).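

Among the compounds shown here, compound 4 is reported in this assay in words only, as "non-toxic", so no step from compound 3 to compound 4 can be read. The compounds shown leave open whether methyl in place of amino shifts the number at all, and no measurement on hand bears on this result.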